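This account rests on a few compounds, and the source may have more. Where it says the series, first, only, none or still open, it means among the compounds named here.

Measured so far in an assay on isolated protein for inhibition of protein deacetylase HDAC6 (Homo sapiens), with a stated time of 60 min; on this read-out higher numbers stand for weaker inhibition and lower numbers for stronger inhibition:
- compound 1 `O=C(CCCCCCn1cc(Nc2ncc3ccn(Cc4ccccc4)c3n2)cn1)NO` — 12.5 nM
- compound 2 `O=C(CCCCCCn1cc(Nc2ncc3ccn(Cc4ccccc4F)c3n2)cn1)NO` — 8.4 nM
- compound 3 `COc1cccc(Cn2ccc3cnc(Nc4cnn(CCCCCCC(=O)NO)c4)nc32)c1` — 28.8 nM

Compound 3 stands at the highest number of the three in this assay: a 2.3-fold higher number from compound 1 to compound 3 (0.36 log units; beyond the scatter) and a 3.4-fold higher number from compound 2 to compound 3 (0.54 log units; beyond the scatter), both modest and both beyond the scatter. Compound 1 and compound 2 sit within the scatter of each other (a 1.5-fold lower number from compound 1 to compound 2 (0.17 log units; within the scatter)).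

Compound 4 `O=C(CCCCCCn1cc(Nc2ncc3ccn(CC4CC4)c3n2)cn1)NO` differs from compound 3 by cyclopropyl in place of 3-methoxyphenyl on a saturated chain carbon bound to an aromatic nitrogen. The two steps that bear on this are the changes on the same saturated chain carbon, a 2.3-fold higher number from compound 1 to compound 3 (0.36 log units; beyond the scatter) and a 3.4-fold higher number from compound 2 to compound 3 (0.54 log units; beyond the scatter); each only varied a substituent on the ring, while here the ring itself leaves. The measured steps at this position are all modest, so no large step is expected, and the direction is uncertain.

The step from compound 3 to compound 4 is expected to be a 1.2-fold lower number from compound 3 to compound 4 (0.06 log units; within the scatter). Compound 4 is estimated at 25 nM in this assay, with a range of 8 nM to 80 nM.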

Compound 4, half-maximal inhibitory concentration: 16 nM
Estimate against measurement, compound 4: 1.6-fold (0.19 log units) above; the range from low to high includes it.
By their numbers in this assay, from the lowest: compounds 2, 1, 4 and 3 (each within the scatter of the next, the first and the last beyond it).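

In this assay, the aromatic ring on the saturated chain carbon bound to an aromatic nitrogen gives way to cyclopropyl with no step beyond the scatter, whichever ring leaves: 3-methoxyphenyl (a 1.8-fold lower number from compound 3 to compound 4 (0.26 log units; within the scatter)), 2-fluorophenyl (a 1.9-fold higher number from compound 2 to compound 4 (0.28 log units; within the scatter)) or phenyl (a 1.3-fold higher number from compound 1 to compound 4 (0.11 log units; within the scatter)). Among these compounds, then, an aromatic ring is not needed at this place to hold the read-out in this range. Nothing at hand explains these steps.

Still open, from the compounds shown here alone, is how an amine, a carboxylic acid or a longer chain would read at this place.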